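Cyclohexyl for Cyclopentyl on a Methoxycarbonyl-bearing Core

A few compounds are considered here, and "the series" means these few. Any claim that something is new, unique, unknown or untested is made for them only; others in the source may bear on it.

Compound 1 `c1ccc(COc2ccc(OCCOCCNC3CCCC3)cc2)cc1` gives 24800 nM in a functional assay on SK-OV-3 cells (Homo sapiens) for inhibition, read by CCK-8 assay, with a stated time of 70 h; on this read-out lower numbers stand for stronger inhibition and higher numbers for weaker inhibition. Compound 2 `c1ccc(COc2ccc(OCCOCCNC3CCCCC3)cc2)cc1` carries cyclohexyl in place of cyclopentyl on an amine nitrogen and gives 7370 nM in this assay; that change made a 3.4-fold lower number from compound 1 to compound 2 (0.53 log units; beyond the scatter). Compound 3 `COC(=O)c1ccc(COc2ccc(OCCOCCNC3CCCC3)cc2)cc1` differs from compound 1 by methoxycarbonyl in place of hydrogen on an aromatic carbon; in this assay compound 3 gives 6990 nM, a step of a 3.5-fold lower number from compound 1 to compound 3 (0.55 log units; beyond the scatter). The values of compound 2 and compound 3 lie within the scatter of each other. Compound 4 `COC(=O)c1ccc(COc2ccc(OCCOCCNC3CCCCC3)cc2)cc1` is not yet measured; it differs from compound 3 by cyclohexyl in place of cyclopentyl on an amine nitrogen, the same change as from compound 1 to compound 2, now made on the core of compound 3. For compound 4 a step of similar size is expected, a 3.0-fold lower number from compound 3 to compound 4 (0.48 log units; beyond the scatter), because the same change gave a 3.4-fold lower number from compound 1 to compound 2 (0.53 log units; beyond the scatter). Compound 4 is therefore expected to give 2300 nM in this assay, estimated between 900 nM and 6000 nM.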

Compound 4, half-maximal inhibitory concentration: 6220 nM
Compound 4: middle estimate off by 2.7-fold (0.43 log units), on the low side; the measured number lies above the stated range.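

In this assay, cyclohexyl in place of cyclopentyl on an amine nitrogen gave a 1.1-fold lower number from compound 3 to compound 4 (0.05 log units; within the scatter), so the step seen on the core of compound 1 did not carry over to the core of compound 3: the same change on two cores in this assay, a 3.4-fold lower number (0.53 log units; beyond the scatter) from compound 1 to compound 2 and a 1.1-fold lower number (0.05 log units; within the scatter) from compound 3 to compound 4, 3.0-fold (0.48 log units) apart, beyond the scatter of two such steps. Methoxycarbonyl in place of hydrogen on an aromatic carbon gave a 1.2-fold lower number from compound 2 to compound 4 (0.07 log units; within the scatter), and its earlier step did not carry over to the core of compound 2 either: the same change on two cores in this assay, a 3.5-fold lower number (0.55 log units; beyond the scatter) from compound 1 to compound 3 and a 1.2-fold lower number (0.07 log units; within the scatter) from compound 2 to compound 4, 3.0-fold (0.48 log units) apart, beyond the scatter of two such steps. The two changes therefore did not add up in these compounds, but this single set does not show why, nor whether the same would hold on any other core.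

The compounds shown leave open how a cycloheptyl group or an isopropyl group on the amine nitrogen would behave on either core. They also leave open whether a carboxylic acid or an amide in place of methoxycarbonyl would behave as methoxycarbonyl does.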